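This account rests on a few compounds, and the source may have more. Where it says the series, first, only, none or still open, it means among the compounds named here.

Measured so far in a functional assay (muscle tissue) with Cavia porcellus as the target; a higher number here means that more compound is needed for the effect, a lower number that less compound is needed:
compound 1 `COC(=O)C1=C(C)N=C(C)/C(=C(\O)OC)C1c1ccc(Cl)cc1Cl`: 640 nM
compound 2 `COC(=O)C1=C(C)N=C(C)/C(=C(\O)OC)C1c1cccc(N(C)C)c1`: 891 nM
compound 3 `COC(=O)C1=C(C)N=C(C)/C(=C(\O)OC)C1c1cccc([N+](=O)[O-])c1`: 3.98 nM

Compound 1 stands second highest of the three numbers. Its nearest neighbour is compound 2, whose value lies within the scatter of that of compound 1, so no order is claimed between the two; compound 3 lies far lower than compound 1. Among the measured compounds shown here, the single step between compounds that differ in one place is a 220-fold lower number from compound 2 to compound 3 (2.35 log units; beyond the scatter), a change on an aromatic carbon.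

Compound 4 `COC(=O)C1=C(C)N=C(C)/C(=C(\O)OC)C1c1ccccc1F` is not yet measured. It differs from compound 1 as follows: 2-fluorophenyl in place of 2,4-dichlorophenyl on a saturated ring carbon. For the measured compounds named here, no measured step bears on this exchange of one aryl group for another; the only measured step concerns a different pair of groups on an aromatic carbon, and its size carries nothing over to a fluoro-for-dichloro swap. What compounds 1 and 2 show is that two aryl groups without a nitro group give values within the scatter of each other. The expected step of a 1.3-fold higher number from compound 1 to compound 4 (0.10 log units; within the scatter) is therefore not beyond the scatter, with wide uncertainty in either direction. Compound 4 is estimated at 800 nM, between 200 nM and 3200 nM, in this assay.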

Compound 4, half-maximal effective concentration: 42.7 nM
For compound 4 the middle estimate is 19-fold (1.27 log units) above the measured one; measured number outside the range, below it.
By their numbers in this assay, from the lowest: compound 3; then compound 4; then compounds 1 and 2 (each within the scatter of the next).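

In this assay the exchange of 2,4-dichlorophenyl for 2-fluorophenyl on the saturated ring carbon gives a 15-fold lower number from compound 1 to compound 4 (1.18 log units; beyond the scatter) and so shows that the number at this position can shift widely between two halogen-bearing aryl groups. Among the compounds shown here, the earlier compounds did not show this: compound 1 and compound 2, neither with a nitro group, lay within the scatter of each other, so the nitro group of compound 3 was the only group tied to a large shift. No measurement at hand accounts for the size of this step.

The exchange alters the halogen and its number together, so the compounds shown leave open which of these changes carries the step. A plain phenyl, a 2-chlorophenyl or a 4-chlorophenyl group in the same place would separate the two.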